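The source may report more compounds than this note shows. Statements on the series, on what has been measured and on what is new or still open speak of the compounds shown alone.

Measured compounds, values in a functional assay on A549 cells (Homo sapiens) for cytotoxicity, read by MTT assay, with a stated time of 72 h; on this read-out lower numbers stand for stronger inhibition and higher numbers for weaker inhibition:

compound 1 `CC1CCN(Cc2ccc3nc(NC(=O)N/N=C/c4cn(Cc5cccc(Cl)c5)c5ccccc45)sc3c2)CC1` gives 2810 nM
compound 2 `Cc1ccc(Cn2cc(/C=N/NC(=O)Nc3nc4ccc(CN5CCC(C)CC5)cc4s3)c3ccccc32)cc1` gives 2180 nM
compound 3 `Cc1ccc(Cn2cc(/C=N/NC(=O)Nc3nc4ccc(CN(C)C)cc4s3)c3ccccc32)cc1` gives 1600 nM

All three numbers sit close together. The step of a 1.3-fold higher number from compound 2 to compound 1 (0.11 log units; within the scatter) and the step of a 1.4-fold lower number from compound 2 to compound 3 (0.13 log units; within the scatter) both fall within the scatter, so no order among compounds 1, 2 and 3 can be read from this assay. Among the compounds with values here, compound 1 and compound 3 have no step computed between them; their two values differ only by a small margin.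

The unmeasured compound 4 `CN(C)Cc1ccc2nc(NC(=O)N/N=C/c3cn(Cc4cccc(Cl)c4)c4ccccc34)sc2c1` differs from compound 3 by 3-chlorophenyl in place of 4-methylphenyl on a saturated chain carbon bound to an aromatic nitrogen. The same change has already been made once in the series, from compound 2 to compound 1, where it is counted as 3-chlorophenyl in place of 4-methylphenyl on a saturated chain carbon bound to an aromatic nitrogen and produced the step of a 1.3-fold higher number from compound 2 to compound 1 (0.11 log units; within the scatter). The place of the change is worded identically in both cases, so it is the same change, carried out on a different core. Within the data shown here, the two cores differ as dimethylamino in place of 4-methylpiperidin-1-yl on a saturated chain carbon bound to an aromatic carbon, a change which itself gave only the step of a 1.4-fold lower number from compound 2 to compound 3 (0.13 log units; within the scatter).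

For compound 4 in this assay the step is therefore expected to resemble the earlier one: a small shift, a 1.3-fold higher number from compound 3 to compound 4 (0.12 log units; within the scatter), resting on the step of a 1.3-fold higher number from compound 2 to compound 1 (0.11 log units; within the scatter) and on the flat behaviour of the core change a 1.4-fold lower number from compound 2 to compound 3 (0.13 log units; within the scatter). The estimate for compound 4 is 2100 nM, expected to fall between 1000 nM and 4200 nM. Since the change has been seen once only, the expectation is loose, and a result anywhere within the scatter of compound 3 would be unsurprising.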

Compound 4, half-maximal inhibitory concentration: 1240 nM
For compound 4 the middle estimate is 1.7-fold (0.23 log units) above the measured one; measured number inside the range.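

In this assay, exchanging 4-methylbenzyl for 3-chlorobenzyl on the core carrying dimethylamino gives a 1.3-fold lower number from compound 3 to compound 4 (0.11 log units; within the scatter), and this step and its counterpart on the core carrying 4-methylpiperidin-1-yl do not differ: the same change on two cores in this assay, a 1.3-fold higher number (0.11 log units; within the scatter) from compound 2 to compound 1 and a 1.3-fold lower number (0.11 log units; within the scatter) from compound 3 to compound 4, 1.7-fold (0.22 log units) apart, within the scatter of two such steps. The other change in the square, dimethylamino in place of 4-methylpiperidin-1-yl, gives a 2.3-fold lower number from compound 1 to compound 4 (0.36 log units; beyond the scatter) on the core with 3-chlorobenzyl, a modest step beyond the scatter, yet it cannot be separated from the same change on the core with 4-methylbenzyl: the same change on two cores in this assay, a 1.4-fold lower number (0.13 log units; within the scatter) from compound 2 to compound 3 and a 2.3-fold lower number (0.36 log units; beyond the scatter) from compound 1 to compound 4, 1.7-fold (0.22 log units) apart, within the scatter of two such steps. Within these four compounds, therefore, neither change shows a dependence on the core, but a single square shows only that no such dependence is visible at this small size of effect; it gives no reliable direction for the benzyl change and does not establish that either change carries over to other cores in the series.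

Going by these compounds, it remains open whether the same flat behaviour would hold with a primary amine or a carboxylic acid in place of dimethylamino. The same question applies to a benzyl group without any substituent in place of 3-chlorobenzyl, where a larger step would test the carry-over more sharply.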